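A bromophenyl swap on the sulfur-bound chain carbon

A few compounds are considered here, and "the series" means these few. Any claim that something is new, unique, unknown or untested is made for them only; others in the source may bear on it.

Measured so far in a functional assay on SW-620 cells (Homo sapiens) for cytotoxicity, read by MTT assay, with stated times of 4 h and 72 h, tested at 5 uM; a higher number here means a weaker inhibitor, a lower number a stronger inhibitor:
- Compound 1 `Cc1cc(Nc2ccc(C(=O)/C=C/c3ccc4ccccc4c3)cc2)n2nc(SCc3ccc(Cl)cc3)nc2n1` gives 570 nM
- Compound 2 `Cc1cc(Nc2ccc(C(=O)/C=C/c3ccc4ccccc4c3)cc2)n2nc(SCc3ccccc3[N+](=O)[O-])nc2n1` gives 960 nM

Within the data shown here, with only one other compound for comparison, compound 2 stands at 960 nM and holds no separate rank, since its value and that of compound 1 lie within the usual scatter of each other.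

The next compound, compound 3 `Cc1cc(Nc2ccc(C(=O)/C=C/c3ccc4ccccc4c3)cc2)n2nc(SCc3ccc(Br)cc3)nc2n1`, keeps the shared core and differs from compound 2 in one place: it carries 4-bromophenyl in place of 2-nitrophenyl on a saturated chain carbon bound to a sulfur.

Among the measured compounds shown here, one measured step bears on this change. It swapped groups at that same place. It put 2-nitrophenyl in place of 4-chlorophenyl and gave a 1.7-fold higher number from compound 1 to compound 2 (0.23 log units; within the scatter). A single step is thin evidence, but it offers no reason to expect a shift beyond the scatter in this assay. For the measured compounds named here, the expected change is a 1.5-fold lower number from compound 2 to compound 3 (0.17 log units; within the scatter), which would be no real step. For compound 3 the estimated value is about 650 nM, with an expected range from 300 nM to 1400 nM.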

Compound 3, half-maximal inhibitory concentration: 370 nM
Estimate against measurement, compound 3: 1.8-fold (0.24 log units) above, within the range that was stated.
By their numbers in this assay, from the lowest: compounds 3, 1 and 2 (each within the scatter of the next, the first and the last beyond it).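

In this assay, among these compounds, this position now shows a step larger than the scatter, a 2.6-fold lower number from compound 2 to compound 3 (0.41 log units; beyond the scatter), whereas the only earlier change here, from 4-chlorophenyl to 2-nitrophenyl, stayed within it. Replacing chloro with bromo on an aromatic carbon gives a 1.5-fold lower number from compound 1 to compound 3 (0.19 log units; within the scatter), so these two halogens cannot be told apart in this assay, and compound 1 cannot be placed clearly apart from either of the other two compounds. The three compounds therefore show that the group on this chain carbon can alter the reading, but only modestly and only between the two ends of this small set, and no measurement shown here explains the difference.

The step from compound 2 to compound 3 changes both the group on the ring and the number in its name, so a 2-bromophenyl or 4-nitrophenyl group would be needed to show which of the two matters. From the compounds shown here alone, it also remains open how this position would respond to something other than a substituted phenyl ring, such as an amine or a longer saturated carbon chain.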